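The source may report more compounds than this note shows. Statements on the series, on what has been measured and on what is new or still open speak of the compounds shown alone.

Working notes on the series. Compound 1 `NC(=O)c1nn(-c2ccc3onc(N)c3c2)c2c(F)c(-c3ccc(N4CCCCC4=O)cc3F)ccc12` is measured in an assay on isolated protein for inhibition of Trypsin (Homo sapiens); on this read-out lower numbers stand for stronger inhibition and higher numbers for weaker inhibition; in this read-out compound 1 gives > 10000 nM, which is a limit of the assay and not a number. Compound 2 `CN(C)Cc1ncccc1-c1ccc(-c2ccc3c(C(N)=O)nn(-c4ccc5onc(N)c5c4)c3c2F)c(F)c1` is the comparator for the next step; in this assay compound 2 gives > 10000 nM, again a limit and not a number. The step that the two limits leave unreadable from compound 1 to compound 2 therefore cannot be read in size, and compound 2 stands at the limit of > 10000 nM in this assay, at which 2 of the 2 values shown sit, with no measured number to place it against.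

Compound 3 `CN(C)CCN(c1ccccc1)c1ccc(-c2ccc3c(C(N)=O)nn(-c4ccc5onc(N)c5c4)c3c2F)c(F)c1` differs from compound 2 in one place: (2-(dimethylamino)ethyl)(phenyl)amino in place of 2-((dimethylamino)methyl)pyridin-3-yl on an aromatic carbon. Among the measured compounds shown here, no measured step bears on this change, and the only step in hand is unreadable, so no direction beyond the scatter can be read for this assay. Compound 3 is expected to sit near the same limit, with an estimated value of 20000 nM (range 5000 nM to 100000 nM), implying an expected step that the limit leaves unreadable from compound 2 to compound 3.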

Compound 3, inhibition constant: > 10000 nM
Compound 3: a limit, no number (the forecaster's own chance of this, stated with the estimate: 85%); the middle value does not contradict the limit.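

Among the compounds shown here, compound 1, compound 2 and compound 3 all stand at a limit, not a number, in this assay, so no new step between them can be read: the limit of > 10000 nM in this assay, at which 3 of the 3 values shown sit. The compounds shown leave open whether exchanging the group on the aromatic carbon changes inhibition in this assay at all.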